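From cyclopropyl to isopropyl on the amide nitrogen

The source may hold more compounds than are shown below. What is called first, only, known or untested is meant among the compounds shown, and "the series" means these compounds.

Measured in a functional assay on MDA-MB-468 cells (Homo sapiens) for antiproliferative activity, read by sulforhodamine B assay, with a stated time of 4 days; on this read-out lower numbers stand for stronger inhibition of growth and higher numbers for weaker inhibition of growth:
compound 1 `COc1cc(Cl)c(-c2nc(SCC(=O)NC3CC3)nc3[nH]cc(C#N)c23)cc1OC`: 62 nM
compound 2 `CCOc1cc(-c2nc(SCC(=O)NC3CC3)nc3[nH]cc(C#N)c23)c(Cl)cc1OC`: 23 nM
compound 3 `CCNC(=O)CSc1nc(-c2cc(OCC)c(OC)cc2Cl)c2c(C#N)c[nH]c2n1`: 64 nM

In this assay, compound 1 at 62 nM sits level with compound 3 at 64 nM, the two values lying within the scatter of each other. Both stand above compound 2, and the gap on the side of compound 1 is a 2.7-fold lower number from compound 1 to compound 2 (0.43 log units; beyond the scatter).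

The next compound, compound 4 `COc1cc(Cl)c(-c2nc(SCC(=O)NC(C)C)nc3[nH]cc(C#N)c23)cc1OC`, changes the core of compound 1 in one place: isopropyl in place of cyclopropyl on an amide-type nitrogen. This puts isopropyl in place of cyclopropyl on an amide-type nitrogen. The closest measured change is ethyl in place of cyclopropyl on an amide-type nitrogen, which gave a 2.8-fold higher number from compound 2 to compound 3 (0.44 log units; beyond the scatter). That step starts from a different compound, and ethyl is not isopropyl, so it is only a partial guide. The step of a 2.7-fold lower number from compound 1 to compound 2 (0.43 log units; beyond the scatter) lies elsewhere in the molecule and says little here. Within the data shown here, no measured compound carries isopropyl. A modest rise in the same direction is therefore expected, smaller than the ethyl step and possibly within the scatter.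

The expected change is a 1.8-fold higher number from compound 1 to compound 4 (0.25 log units; within the scatter).

In this assay, compound 4 is estimated at 110 nM, with an expected range of 50 nM to 240 nM.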

Compound 4, concentration for 50% growth inhibition: 102 nM
Beside the measured number, compound 4's estimate is 1.1-fold (0.03 log units) above it; measured number inside the range.
By their numbers in this assay, from the lowest: compound 2; then compounds 1, 3 and 4 (each within the scatter of the next).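

Opening the three-membered ring of cyclopropyl into isopropyl, with the count of 3 carbon atoms unchanged, gives a 1.6-fold higher number from compound 1 to compound 4 (0.22 log units; within the scatter) in this assay, so on the core of compound 1 this amide-type nitrogen keeps its read-out within the scatter without the ring. Among these compounds, the only earlier change at this nitrogen, cyclopropyl to ethyl, gave a 2.8-fold higher number from compound 2 to compound 3 (0.44 log units; beyond the scatter), a step beyond the scatter, but it started from a different compound and entered a different group, so the two steps cannot show whether the group or the starting compound sets their size. Nothing measured here explains either step.

The compounds shown leave open how isopropyl would read on the core of compound 2, the one place where a direct test against the ethyl step would be possible. They also leave open how this amide-type nitrogen would respond to cyclobutyl, to tert-butyl, or to a longer chain ending in an amine or a carboxylic acid.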